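Removing the bromo from compound 2

The source may hold more compounds than are shown below. What is called first, only, known or untested is meant among the compounds shown, and "the series" means these compounds.

Measured in a functional assay on SiHa cells (Homo sapiens) for inhibition, read by CCK-8 assay, with a stated time of 72 h, tested at 10 uM; a higher number here means more inhibition of growth at the concentration tested, a lower number less inhibition of growth:
- Compound 1 `Cc1ccc(NC(=O)C2(C(=O)Nc3ccc(Nc4ncc5cc(C(=O)N(C)C)n(C6CCCC6)c5n4)cc3)CC2)cc1`: 104%
- Compound 2 `CN(C)C(=O)c1cc2cnc(Nc3ccc(NC(=O)C4(C(=O)Nc5cccc(Br)c5)CC4)cc3)nc2n1C1CCCC1`: 92.5%

Compound 2 holds the lower of the two numbers, and compound 1 stands above it, beyond the scatter. Compound 3 `CN(C)C(=O)c1cc2cnc(Nc3ccc(NC(=O)C4(C(=O)Nc5ccccc5)CC4)cc3)nc2n1C1CCCC1` is compound 2 with hydrogen in place of bromo on an aromatic carbon. The 3-bromophenyl thus becomes phenyl.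

Among the measured compounds shown here, only one measured step bears on this change: a number 11.5 percentage points lower from compound 1 to compound 2 (beyond the scatter), a modest one, with 3-bromophenyl in place of 4-methylphenyl. It bears only indirectly, since neither measured compound carries an unsubstituted phenyl, and it cannot show how much of the gap belongs to the bromo. With compound 1 at 104% and compound 2 at 92.5%, a large move is not expected. A small rise is expected instead, most likely within the scatter. In this assay the expected step is a number 4.5 percentage points higher from compound 2 to compound 3 (within the scatter). The estimate for compound 3 is 97%, with an expected range from 85% to 108%.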

Compound 3, percent growth inhibition at one concentration: 106%
Beside the measured number, compound 3's estimate is 9 percentage points below it; the measured number falls inside the stated range.
By their numbers in this assay, from the lowest: compound 2; then compounds 1 and 3 (each within the scatter of the next).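

In this assay the removal of the bromo gives a number 13.5 percentage points higher from compound 2 to compound 3 (beyond the scatter) and so isolates the bromo at this position, whereas the earlier step exchanged 3-bromophenyl for 4-methylphenyl and could not separate the loss of the methyl from the arrival of the bromo. The second new step, a number 2 percentage points higher from compound 1 to compound 3 (within the scatter), puts hydrogen in place of methyl and shows no readable difference between the phenyl of compound 3 and the 4-methylphenyl of compound 1, so among these three compounds the gap belongs to the 3-bromophenyl of compound 2 and not to the methyl. No measurement shown offers an explanation for the size or direction of either step.

The compounds shown leave open whether the lower number in compound 2 is particular to bromine or to its place on the ring, a question that 4-bromophenyl, 3-chlorophenyl or 3-methylphenyl would address. They also leave open how far this ring tolerates larger or charged additions, such as a methoxy group, an amine or a carboxylic acid, and a single-concentration read-out cannot separate compound 1 from compound 3.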